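The source may report more compounds than this note shows. Statements on the series, on what has been measured and on what is new or still open speak of the compounds shown alone.

Measured so far:
- compound 1 `Cc1cc(C)c(CN2CCc3c(Cl)cc([C@H](CO)[C@H]4CCCO4)c(Cl)c3C2=O)c(=O)[nH]1`: 40 nM
- compound 2 `Cc1cc(C)c(CN2CCc3c(Cl)cc(C(CO)c4ccon4)c(Cl)c3C2=O)c(=O)[nH]1`: 7960 nM; 273 nM (2 entries)
- compound 3 `COC(c1cc(Cl)c2c(c1Cl)C(=O)N(Cc1c(C)cc(C)[nH]c1=O)CC2)C1CCS(=O)(=O)CC1`: 430 nM; 18 nM (2 entries)

The shared core carries a dimethyl pyridone and two chloro groups; the three compounds differ in the side group on the aromatic ring of the core. Within the data shown here, in an assay on cells for inhibition of histone-lysine N-methyltransferase EZH2 (Homo sapiens), read by ELISA, with a stated time of 72 h (a higher number here means a weaker inhibitor, a lower number a stronger inhibitor), compound 1 gives 40 nM, the only single number in the set; compound 2 and compound 3 each have two entries that lie far apart, as the several entries of compound 2 in this assay, 7960 nM; 273 nM (2 entries) and the several entries of compound 3 in this assay, 430 nM; 18 nM (2 entries) show, so neither gives a firm anchor.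

Compound 4 `Cc1cc(C)c(CN2CCc3c(Cl)cc(-c4c(C)noc4C)c(Cl)c3C2=O)c(=O)[nH]1` differs from compound 1 in one place: a group of 7 heavy atoms (5 carbon, 1 nitrogen, 1 oxygen; one five-membered aromatic ring with 2 hetero atoms) in place of a group of 8 heavy atoms (6 carbon, 2 oxygen; one five-membered non-aromatic ring with 1 hetero atom), on an aromatic carbon. The hydroxymethyl-bearing side chain with its saturated ring is thus replaced by a flat aromatic heterocycle, and the one hydrogen-bond donor is lost.

Among the measured compounds shown here, with no measured pair of this kind, the direction can only be guessed. The nearest comparison is compound 2, which also carries a five-membered aromatic heterocycle and shows 7960 nM; 273 nM (2 entries), weaker than compound 1. A moderate loss of potency is therefore expected, with wide uncertainty. Compound 4 is estimated at 200 nM, between 40 nM and 1500 nM. This estimate means an expected step of a 5.0-fold higher number from compound 1 to compound 4 (0.70 log units; beyond the scatter), toward weaker inhibition.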

Compound 4, half-maximal inhibitory concentration: 17 nM
Compound 4: the middle estimate sits 12-fold (1.07 log units) above what was measured, outside the stated range (below it).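

In this assay, the change gives a 2.4-fold lower number from compound 1 to compound 4 (0.37 log units; beyond the scatter). At this aromatic carbon, then, compound 4 keeps good potency at 17 nM with a five-membered aromatic ring in place of a side group with a hydrogen-bond donor, a non-aromatic ring and two defined stereocentres. No measurement shown explains why the number falls with this change.

Still open, from the compounds shown here alone, is whether the two methyl groups of the 3,5-dimethyl-1,2-oxazol-4-yl group matter, which the same ring without them, or a phenyl ring at this carbon, could help to show. Compound 2 also offers no firm second reference for a five-membered aromatic ring in the side group, as its two entries lie far apart: the several entries of compound 2 in this assay, 7960 nM; 273 nM (2 entries)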